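A few compounds are considered here, and "the series" means these few. Any claim that something is new, unique, unknown or untested is made for them only; others in the source may bear on it.

Measured in a functional assay on AGS cells (Homo sapiens) for antiproliferative activity, read by MTT assay, with a stated time of 48 h; a lower number here means a stronger inhibitor of growth, a higher number a weaker inhibitor of growth:
- compound 1 `COc1ccc(Cn2cnc3c(N(C)c4ccc(OC)cc4)ncnc32)cc1` gives > 100000 nM
- compound 2 `COc1ccc(N(C)c2ncnc3c2ncn3Cc2ccc(OC)c(OC)c2)cc1` gives > 100000 nM

Both entries are limits of the assay, not numbers. Compound 2 stands at the limit of > 100000 nM in this assay, at which 2 of the 2 values shown sit, so the starting point for the next step is a limit.

Compound 3 `COc1ccc(Cn2cnc3c(Cl)ncnc32)cc1OC` differs from compound 2 by chloro in place of (4-methoxyphenyl)(methyl)amino on an aromatic carbon. In words, chloro takes the place of (4-methoxyphenyl)(methyl)amino on an aromatic carbon.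

Going by the values given here, the only measured step is a step that the two limits leave unreadable from compound 1 to compound 2. Its size cannot be read, and it does not touch the group that leaves here, so it gives no measure for this change. Among the compounds with values here, the series holds no measured example of this replacement, and the expectation is therefore loose.

With compound 2 at > 100000 nM, a limit, any readable value for compound 3 in this assay would lie on the side of stronger growth inhibition. The expected change is an at least 2.5-fold lower number from compound 2 to compound 3 (0.39 log units; beyond the scatter), and it is only an estimate. A second limit remains a real possibility. For compound 3 the estimated value is 40000 nM, with an expected range of 8000 nM to 100000 nM.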

Compound 3, concentration for 50% growth inhibition: > 100000 nM
Compound 3 gave a limit, no number (the forecaster's own chance of this, stated with the estimate: 45%); middle value at least 2.5-fold (0.39 log units) away from the limit.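

In this assay, going by these compounds alone, compound 3 gives > 100000 nM as a limit and not a number, so the step from compound 2 to compound 3 cannot be read and no new step arises. Still open is whether any change among compound 1, compound 2 and compound 3 alters growth inhibition, because all readings sit at one limit: the limit of > 100000 nM in this assay, at which 3 of the 3 values shown sit.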